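Pyridinyl for thiadiazolyl on a bombesin receptor subtype-3 agonist

The compounds below may be only part of what the source reports. "The series", "measured", "known", "first", "only" and "open" are said of these compounds alone.

Measured compounds:
- compound 1, `CCC(C)(C)Cc1c[nH]c(CCc2ccc(-n3ccnn3)cc2)n1`, 57 nM
- compound 2, `CCC(C)(C)Cc1c[nH]c(CCc2ccc(-c3cnccn3)cc2)n1`, 11 nM
- compound 3, `CCC(C)(C)Cc1c[nH]c(CCc2ccc(-c3csnn3)cc2)n1`, 11 nM

The three compounds share one core and differ only in the aromatic group placed para to a large group. In a functional assay on HEK293 cells for agonist activity at Bombesin receptor subtype-3 (Mus musculus), read by luminescence and calcium flux, with a stated time of 10 min (on this read-out lower numbers stand for an effect already at smaller amounts and higher numbers for an effect only at larger amounts of compound), compound 1 gives 57 nM, while compound 2 gives 11 nM and compound 3 gives 11 nM. The step of a 5.2-fold lower number from compound 1 to compound 2 (0.71 log units; beyond the scatter) and the step of a 5.2-fold lower number from compound 1 to compound 3 (0.71 log units; beyond the scatter) are both beyond the scatter, whereas the step of no change at the digits printed from compound 2 to compound 3 (within the scatter) is not. Compound 3 thus stands level with compound 2 and together with it at the lowest number of the three.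

Compound 4, `CCC(C)(C)Cc1c[nH]c(CCc2ccc(-c3cccnc3)cc2)n1`, has not yet been measured. It differs from compound 3 by pyridin-3-yl in place of 1,2,3-thiadiazol-4-yl on an aromatic carbon. Among the measured compounds shown here, no measured step exchanges these two groups directly; the nearest guide is that compound 2 and compound 3 carry different rings at this place yet give the same number, while only compound 1 departs from them. On that basis compound 4 is expected to stay close to compound 3, with an estimated step of a 1.4-fold higher number from compound 3 to compound 4 (0.13 log units; within the scatter). The estimate for compound 4 in this assay is 15 nM, within 5 nM to 45 nM.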

Compound 4, half-maximal effective concentration: 4.3 nM
Estimate against measurement, compound 4: 3.5-fold (0.54 log units) above; measured number below the stated range.
By their numbers in this assay, from the lowest: compound 4; then compounds 2 and 3 (each within the scatter of the next); then compound 1.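

In this assay, among the compounds shown here, the place para to a large group had so far given the same number with two different rings, but it now separates them: pyridin-3-yl gives a 2.6-fold lower number from compound 3 to compound 4 (0.41 log units; beyond the scatter) and a 2.6-fold lower number from compound 2 to compound 4 (0.41 log units; beyond the scatter). The ring at this place therefore still moves the number among rings that had looked equivalent, and the span across the series widens to a 13-fold lower number from compound 1 to compound 4 (1.12 log units; beyond the scatter), a large step. No measurement here accounts for this order.

The compounds shown leave open whether the ring nitrogen's placement matters, as pyridin-2-yl or pyridin-4-yl in place of pyridin-3-yl would test. They also leave open whether an amine or a carboxylic acid added to the pyridin-3-yl ring would keep the number this low.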